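A Fluorine Swap Without a Measured Starting Point

The source may report more compounds than this note shows. Statements on the series, on what has been measured and on what is new or still open speak of the compounds shown alone.

Before a compound is taken further, it helps to know whether it harms living cells, and that question is followed here in an ADME assay on RAW264.7 cells (Mus musculus) for cytotoxicity, read by MTT assay; a lower number here means a stronger inhibitor, a higher number a weaker inhibitor. Compound 1 (`COc1ccc(C(=O)/C=C/C=C/c2ccc(N(C)C)cc2)cc1`) gives > 100000 nM, which is a limit of the assay and not a number. Compound 2 (`CN(C)c1ccc(/C=C/C=C/C(=O)c2ccccc2O)cc1`) gives "not determined" (no result reported), so it has no single number to stand on. Among the compounds with values here, the only reading so far, from compound 1, is the limit of > 100000 nM in this assay, at which 1 of the 2 values shown sits.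

Compound 3 (`CN(C)c1ccc(/C=C/C=C/C(=O)c2ccc(F)cc2)cc1`) has not yet been measured. The structural change is 4-fluorophenyl in place of 2-hydroxyphenyl on a carbonyl carbon. In plain words, 4-fluorophenyl takes the place of 2-hydroxyphenyl on a carbonyl carbon.

Without a number for compound 2, no step can be read from the data, and no direction can be argued for. The expectation is therefore for no step beyond the usual scatter. Within the data shown here, the only guide is compound 1 at > 100000 nM, which is again a limit. A limit rather than a number is also a likely outcome for compound 3. If a number is obtained, compound 3 is estimated at 80000 nM, with an expected range of 20000 nM to 200000 nM.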

Compound 3, half-maximal inhibitory concentration: > 100000 nM
Compound 3 ended at the assay's limit (the forecaster's own chance of this, stated with the estimate: 65%); middle value at least 1.2-fold (0.09 log units) away from the limit.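

In this assay compound 3 gives > 100000 nM, which is a limit of the assay and not a number. No step can be read from this result, either between compound 1 and compound 3 or between compound 2 and compound 3. The compounds shown leave open whether 4-fluorophenyl in place of 2-hydroxyphenyl changes the reading at all.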